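Adding a methyl to the amino group of compound 3

The source may hold more compounds than are shown below. What is called first, only, known or untested is meant among the compounds shown, and "the series" means these compounds.

In a functional assay on the whole organism with Rattus norvegicus as the target (a lower number here means that less compound is needed, a higher number that more compound is needed for the effect), compound 3 `CCOC(=O)C(=O)Nc1cccc(N)c1C#N` has the lowest number of the three measured compounds, at 0.07 mg/kg. Compound 1 `CCOC(=O)C(=O)Nc1cccc(N(C)C)c1C#N` gives 4.2 mg/kg, and compound 2 `CCOC(=O)C(=O)Nc1cccc(OC)c1C#N` gives 55.5 mg/kg. These three differ only in the group on one aromatic carbon: amino, dimethylamino or methoxy.

Compound 4 `CCOC(=O)C(=O)Nc1cccc(NC)c1C#N` has not yet been measured. It carries methylamino where compound 3 carries amino, and the change is methyl in place of hydrogen on a nitrogen on an aromatic ring.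

The measured step closest to this change is a 60-fold lower number from compound 1 to compound 3 (1.78 log units; beyond the scatter), with amino in place of dimethylamino. Read backwards, it links dimethylamino to a higher number than amino, and methylamino is the intermediate structure of the two. The other two steps, a 13-fold higher number from compound 1 to compound 2 (1.12 log units; beyond the scatter) and a 790-fold lower number from compound 2 to compound 3 (2.90 log units; beyond the scatter), are also large, but both involve methoxy and bear on this change only indirectly. Among the compounds with values here, no measured compound shows how the difference divides between the two methyl groups of compound 1, so the range stays wide.

A rise smaller than the closest step is expected, and the estimated step is a 7.1-fold higher number from compound 3 to compound 4 (0.85 log units; beyond the scatter). Compound 4 is estimated at 0.5 mg/kg, with an expected range of 0.12 mg/kg to 2.5 mg/kg.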

Compound 4, dose for half-maximal effect: 0.1 mg/kg
Compound 4: the middle estimate sits 5.0-fold (0.70 log units) above what was measured; measured number outside the range, below it.
By their numbers in this assay, from the lowest: compounds 3 and 4 (each within the scatter of the next); then compound 1; then compound 2.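

In this assay, a single methyl on this nitrogen leaves the number within the scatter of the amino compound, with a 1.4-fold higher number from compound 3 to compound 4 (0.15 log units; within the scatter) as the whole effect of the change. The large penalty of dimethylamino therefore appears only with the second methyl, as a 42-fold lower number from compound 1 to compound 4 (1.62 log units; beyond the scatter) places nearly all of the earlier amino to dimethylamino difference on that one further change, while the wide gap to methoxy persists with methylamino, at a 560-fold lower number from compound 2 to compound 4 (2.74 log units; beyond the scatter) in this series. The data shown offer no explanation for this uneven split between the two methyl groups.

Still open, on these data alone, is whether the nitrogen accepts anything larger than one methyl when a hydrogen remains on it, as an ethyl, a longer chain or an acetyl group would test, and whether a pyrrolidine ring, which ties both substituent positions on the nitrogen together, would follow dimethylamino. Also open, as far as these compounds go, is whether the same pattern of methyl steps would hold with a group other than the ethyl ester on the shared core.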